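Pentafluorosulfanyl thiohydantoins: positional isomers in VCaP proliferation

A few compounds are considered here, and "the series" means these few. Any claim that something is new, unique, unknown or untested is made for them only; others in the source may bear on it.

Measured so far:
compound 1 `CC1(C)C(=O)N(c2ccc(S(F)(F)(F)(F)F)cc2)C(=S)N1c1ccc(C(F)(F)F)cc1`, 100000 nM
compound 2 `CC1(C)C(=O)N(c2ccc(S(F)(F)(F)(F)F)cc2)C(=S)N1c1cccc(C(F)(F)F)c1`, 100000 nM
compound 3 `CC1(C)C(=O)N(c2cccc(S(F)(F)(F)(F)F)c2)C(=S)N1c1ccc(C(F)(F)F)cc1`, 54200 nM

In a functional assay on VCaP cells (Homo sapiens) for antiproliferative activity, read by propidium iodide staining, with a stated time of 96 h (on this read-out lower numbers stand for stronger inhibition and higher numbers for weaker inhibition), compound 1 gives 100000 nM and compound 2 gives 100000 nM. The change between them, (3-(trifluoromethyl)phenyl in place of 4-(trifluoromethyl)phenyl on an amide-type nitrogen in a ring), made a step of no change at the digits printed from compound 1 to compound 2 (within the scatter). Compound 3 gives 54200 nM in this assay; its two comparisons with compound 1 and compound 2 both fall within the scatter, so no order among the three is read. How the core of compound 3 differs from the core of compound 1 is not broken down here.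

Compound 4 `CC1(C)C(=O)N(c2cccc(S(F)(F)(F)(F)F)c2)C(=S)N1c1cccc(C(F)(F)F)c1` is not yet measured. It differs from compound 3 by 3-(trifluoromethyl)phenyl in place of 4-(trifluoromethyl)phenyl on an amide-type nitrogen in a ring, the same change as that from compound 1 to compound 2, at an identically described place. Because no change at the digits printed from compound 1 to compound 2 (within the scatter), the step from compound 3 to compound 4 is expected to be about a 1.1-fold higher number from compound 3 to compound 4 (0.04 log units; within the scatter). Compound 4 is therefore estimated at 60000 nM in this assay, between 25000 nM and 100000 nM.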

Compound 4, half-maximal inhibitory concentration: 100000 nM
Compound 4: middle estimate off by 1.7-fold (0.22 log units), on the low side; the range from low to high includes it.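

With 3-(trifluoromethyl)phenyl in place of 4-(trifluoromethyl)phenyl, this assay shows a 1.8-fold higher number from compound 3 to compound 4 (0.27 log units; within the scatter), and the two cores can be compared directly: the same change on two cores in this assay, no change at the digits printed (within the scatter) from compound 1 to compound 2 and a 1.8-fold higher number (0.27 log units; within the scatter) from compound 3 to compound 4, 1.8-fold (0.27 log units) apart, within the scatter of two such steps. The change therefore carries from one core to the other here without a readable difference between the steps. This rests on two cores only and does not show that the change would be equally silent on other cores, or on compounds with much lower numbers.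

On these data alone, whether a nitrile in place of the trifluoromethyl group, or an amine in place of the pentafluorosulfanyl group, would give a lower number in this assay remains open. So does the effect of a longer chain in place of the two methyl groups.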